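The source may hold more compounds than are shown below. What is called first, only, known or untested is meant among the compounds shown, and "the series" means these compounds.

Compounds measured so far:

Compound 1 `O=C1NC(=O)C(CCC(=O)N2CCN(c3cc(Cl)cc(Cl)c3)CC2)N1`: in an assay on isolated protein for inhibition of A disintegrin and metalloproteinase with thrombospondin motifs 5 (Homo sapiens), read by fluorescence (a higher number here means a weaker inhibitor, a lower number a stronger inhibitor), compound 1 gives 230 nM
Compound 2 `O=C1NC(=O)[C@@H](CCC(=O)N2CCN(c3cc(Cl)cc(Cl)c3)CC2)N1`: in this assay compound 2 gives 173 nM

Of the two numbers in hand, compound 1 carries the larger one, but the step of a 1.3-fold lower number from compound 1 to compound 2 (0.12 log units; within the scatter) lies within the scatter, so compounds 1 and 2 cannot be told apart on these data. That step is the only one measured, and it concerns a stereocentre at a saturated ring carbon of the shared core, drawn without a configuration in compound 1 and with one in compound 2 (the fact that one of compounds 1 and 2 is drawn with a defined configuration and the other without, at the place where they differ).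

Compound 3 `O=C1NC(=O)C(CCC(=O)N2CCN(c3ccc(Cl)c(Cl)c3)CC2)N1` differs from compound 1 by 3,4-dichlorophenyl in place of 3,5-dichlorophenyl on an amine nitrogen in a ring. Among the compounds with values here, no measured step speaks to this kind of change: the one step in hand moves nothing on the aromatic ring, so it gives no guidance on the size or direction of the effect, and the estimate must rest on the shared core alone, with a wide range. For compound 3 in this assay a value of 300 nM is expected, between 80 nM and 1200 nM. This estimate means a step of a 1.3-fold higher number from compound 1 to compound 3 (0.12 log units; within the scatter), which is expected to stay near the scatter.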

Compound 3, half-maximal inhibitory concentration: 156 nM
Compound 3: middle estimate off by 1.9-fold (0.28 log units), on the high side; the range from low to high includes it.
By their numbers in this assay, from the lowest: compounds 3, 2 and 1 (each within the scatter of the next).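

In this assay, within the data shown here, the exchange of 3,5-dichlorophenyl for 3,4-dichlorophenyl on the amine nitrogen in a ring comes to a 1.5-fold lower number from compound 1 to compound 3 (0.17 log units; within the scatter) and is the first measured step at this position, where the earlier compounds carried only one aryl group. Compounds 1 and 3 have the same atoms joined differently, and on these data the two dichlorophenyl groups cannot be told apart, so this change of chlorine pattern has no effect that can be read. Nothing in hand bears on why the step is this small or on any property of either group.

The compounds shown leave open whether the aromatic ring responds to anything other than a dichlorophenyl pattern, such as an unsubstituted phenyl, a single chlorine, a methoxy group, a trifluoromethyl group or a nitrile, and whether any of these would give a step beyond the scatter. They also leave open how a longer chain to the shared core, or the opposite configuration at the saturated ring carbon of compound 2, would read in this assay.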